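This account rests on a few compounds, and the source may have more. Where it says the series, first, only, none or still open, it means among the compounds named here.

Measured compounds:
- Compound 1, `O=C(O)c1ccc(OCC(O)COc2ccc3c(O)c([N+](=O)[O-])c(=O)oc3c2)cc1`. In a functional assay on ileum (Cavia porcellus) for antagonist activity (a higher number here means a weaker inhibitor, a lower number a stronger inhibitor), compound 1 gives > 10000 nM, which is a limit of the assay rather than a number.
- Compound 2, `CCCc1ccccc1OCC(O)COc1ccc2c(O)c([N+](=O)[O-])c(=O)oc2c1`, in this assay compound 2 gives 110 nM.
- Compound 3, `CCCc1cc(F)ccc1OCC(O)COc1ccc2c(O)c([N+](=O)[O-])c(=O)oc2c1`, in this assay compound 3 gives 140 nM.

Compound 3 holds the highest of the two numbers, and its nearest neighbour is compound 2: a 1.3-fold higher number from compound 2 to compound 3 (0.10 log units; within the scatter). Compound 1 sits at the limit (the limit of > 10000 nM in this assay, at which 1 of the 3 values shown sits).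

Compound 4, `CC(C)c1ccccc1OCC(O)COc1ccc2c(O)c([N+](=O)[O-])c(=O)oc2c1`, has not been measured. It differs from compound 3 in one place: 2-isopropylphenyl in place of 4-fluoro-2-propylphenyl on an oxygen on a saturated carbon. Among the measured compounds shown here, two measured steps bear on this. The large shifts an at least 90-fold lower number from compound 1 to compound 2 (1.95 log units; beyond the scatter) and an at least 71-fold lower number from compound 1 to compound 3 (1.85 log units; beyond the scatter) show that a phenyl bearing a propyl group on an oxygen on a saturated carbon gives a much lower number than 4-carboxyphenyl at that place. The step of a 1.3-fold higher number from compound 2 to compound 3 (0.10 log units; within the scatter) shows that fluoro in place of hydrogen on an aromatic carbon changes nothing beyond the scatter. Removing the fluoro should therefore leave the number about where it is. For the measured compounds named here, no measured pair compares propyl with isopropyl, so that part of the change rests on no evidence. Compound 4 is expected to stay close to compound 3, with a 1.1-fold lower number from compound 3 to compound 4 (0.03 log units; within the scatter), a step not expected to exceed the scatter. The estimate for compound 4 in this assay is 130 nM, between 50 nM and 350 nM.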

Compound 4, half-maximal inhibitory concentration: 160 nM
The estimate for compound 4 lay 1.2-fold (0.09 log units) below the measured number; measured number inside the range.
By their numbers in this assay, from the lowest: compounds 2, 3 and 4 (each within the scatter of the next). At a limit, above all of these: compound 1.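

With isopropyl in place of propyl on an aromatic carbon, this assay shows a 1.5-fold higher number from compound 2 to compound 4 (0.16 log units; within the scatter), and with the fluoro also gone it shows a 1.1-fold higher number from compound 3 to compound 4 (0.06 log units; within the scatter), so this position tolerates both a propyl and an isopropyl group with no change beyond the scatter. The 2-isopropylphenyl group also keeps the large difference from 4-carboxyphenyl, with an at least 62-fold lower number from compound 1 to compound 4 (1.79 log units; beyond the scatter). That step is a minimum, since compound 1 stands at a limit rather than a number: the limit of > 10000 nM in this assay, at which 1 of the 4 values shown sits.

Still open, going by these compounds, is whether a plain phenyl without an alkyl group, or one carrying a longer chain such as butyl, would keep the number this low. On these data alone, it is also open whether an amine in place of the carboxylic acid would bring the same large rise as 4-carboxyphenyl.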